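The source may hold more compounds than are shown below. What is called first, only, known or untested is meant among the compounds shown, and "the series" means these compounds.

Of the compounds shown here, three have so far been measured in a functional assay on HEL cells (Homo sapiens) for cytotoxicity; a lower number here means that less compound is tolerated, a higher number that more compound is tolerated. Compound 1 `CCC(C)C1NC(=O)N(C2CCCCC2)C1=O` gives only a limit of the assay, > 100 ug/mL. Compound 1 is the one that accounts for (the limit of > 100 ug/mL in this assay, at which 1 of the 3 values shown sits). Compound 2 `CCC(C)C(NC(=O)n1nnc2ccccc21)C(=O)NC(c1ccccc1)c1ccccc1` gives 80 ug/mL in this assay. Compound 3 `CCC(C)C(NC(=O)n1nnc2ccccc21)C(=O)NC1CCCCC1` gives 80 ug/mL in this assay, which sits level with compound 2 at the digits shown, the two differing by nothing beyond the usual scatter. For the measured compounds named here, with one value resting at a limit, only two numbers remain to compare, and they agree.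

Compound 4 `CCC(C)C(NC(=O)n1nnc2ccccc21)C(=O)NCc1ccccc1` differs from compound 3 in one place: benzyl in place of cyclohexyl on an amide-type nitrogen. Going by the values given here, no pair of measured compounds differs in only one place, so no measured step shows how such a change moves the read-out in this assay. The step of no change at the digits printed from compound 3 to compound 4 (within the scatter) is expected to stay within the scatter, with no direction beyond it. For compound 4 the estimated value in this assay is 80 ug/mL, with a range from 40 ug/mL to 100 ug/mL.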

Compound 4, minimum cytotoxic concentration: 200 ug/mL
Compound 4: middle estimate off by 2.5-fold (0.40 log units), on the low side; measured number outside the range, above it.
By their numbers in this assay, from the lowest: compounds 2 and 3 (each within the scatter of the next); then compound 4.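

In this assay, the group on this amide-type nitrogen now shows a measured effect: benzyl in place of cyclohexyl gives a 2.5-fold higher number from compound 3 to compound 4 (0.40 log units; beyond the scatter). Hydrogen in place of phenyl, on the saturated chain carbon bound to an amide-type nitrogen and an aromatic carbon, gives a 2.5-fold higher number from compound 2 to compound 4 (0.40 log units; beyond the scatter). Compound 2 and compound 3 alone, level at the digits printed, did not show that this nitrogen substituent can change the read-out, although both steps are modest and both lead to the same compound.

As far as these compounds go, whether a longer chain or an amine in place of benzyl on this nitrogen would move the number further remains open. Compound 1 gives only a limit, so it cannot be placed in order with the other compounds: the limit of > 100 ug/mL in this assay, at which 1 of the 4 values shown sits.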